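A 4-nitrophenyl group joins the chain of compound 3

The source may hold more compounds than are shown below. What is called first, only, known or untested is meant among the compounds shown, and "the series" means these compounds.

Of the compounds shown here, three sharing one core have been tested in a functional assay on SK-BR-3 cells (Homo sapiens) for antiproliferative activity, read by MTT assay, with a stated time of 72 h; a higher number here means a weaker inhibitor, a lower number a stronger inhibitor. Compound 3 `C/C=C1/[C@H](O[C@@H]2O[C@H](CO)[C@@H](O)[C@H](O)[C@H]2O)OC=C(C(=O)OC)[C@H]1CC(=O)OCC`, an ethyl ester, is known only as a limit, > 15000 nM. Compound 1 `C/C=C1/[C@H](O[C@@H]2O[C@H](CO)[C@@H](O)[C@H](O)[C@H]2O)OC=C(C(=O)OC)[C@H]1CC(=O)OCCCc1ccc(OC)c(OC)c1` is likewise known only as a limit, > 20000 nM. Compound 2 `C/C=C1/[C@H](O[C@@H]2O[C@H](CO)[C@@H](O)[C@H](O)[C@H]2O)OC=C(C(=O)OC)[C@H]1CC(=O)OCCC1CCCCC1` gives a real number, 2000 nM.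

Compound 4 `C/C=C1/[C@H](O[C@@H]2O[C@H](CO)[C@@H](O)[C@H](O)[C@H]2O)OC=C(C(=O)OC)[C@H]1CC(=O)OCCc1ccc([N+](=O)[O-])cc1` departs from compound 3 by 4-nitrophenyl in place of hydrogen on a saturated chain carbon, two bonds along the chain from an oxygen next to a carbonyl group.

For the measured compounds named here, two measured steps bear on this change. Removing cyclohexyl at that carbon gave an at least 7.5-fold higher number from compound 2 to compound 3 (0.87 log units; beyond the scatter), which suggests that a large group can lower the number. Compound 1 goes against that pattern: swapping its 3,4-dimethoxybenzyl for cyclohexyl gave an at least 10-fold lower number from compound 1 to compound 2 (1.00 log units; beyond the scatter). The new group is aromatic, as in compound 1, so only a partial gain seems likely. The expected change, towards a stronger inhibitor, is an at least 2.1-fold lower number from compound 3 to compound 4 (0.33 log units; beyond the scatter). For compound 4 the estimated value is 7000 nM, with an expected range of 2000 nM to 25000 nM.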

Compound 4, half-maximal inhibitory concentration: > 20000 nM
Compound 4 was reported as a limit; the forecaster's own chance of this, stated with the estimate: 40%; middle value at least 2.8-fold (0.45 log units) from the limit.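

In this assay, 4-nitrophenyl in place of cyclohexyl at this carbon gives an at least 10-fold higher number from compound 2 to compound 4 (1.00 log units; beyond the scatter), so the gain seen with compound 2 does not carry over to this aromatic group. Compound 4 is known only as a limit, and the steps to it from compound 3 and compound 1 cannot be read, since each of those pairs has limits at both ends: the limit of > 20000 nM in this assay, at which 2 of the 4 values shown sit. Compound 4 thus joins compound 1 as a second aromatic ester without a measured value, though compound 3, with no ring on its chain, is also only a limit, so the aromatic ring alone cannot account for this.

On these data alone, whether a plain phenyl or a 4-aminophenyl would give a measurable value remains open. So does whether another saturated ring, such as cyclopentyl, would match cyclohexyl.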